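Benzyl in Place of Hydrogen on an Aromatic Nitrogen

The source may hold more compounds than are shown below. What is called first, only, known or untested is meant among the compounds shown, and "the series" means these compounds.

Of the compounds shown here, three sharing one core have been measured in a physicochemical assay for lipophilicity, read by HPLC, at pH 7.4; on this read-out higher numbers stand for higher lipophilicity and lower numbers for lower lipophilicity. Compound 1 `NCc1csc(NC(=O)c2ccc(Cl)cc2)n1` gives 1.6, compound 2 `NCc1csc(NC(=O)c2cc3ccccc3[nH]2)n1` gives 1.4, and compound 3 `NCc1csc(NC(=O)c2ccn[nH]2)n1` gives 0.1. On these numbers compound 2 stands second highest of three: its nearest neighbour is compound 1, within the usual scatter, and its furthest is compound 3, beyond the scatter.

Compound 4 `NCc1csc(NC(=O)c2cc3ccccc3n2Cc2ccccc2)n1` differs from compound 2 by benzyl in place of hydrogen on an aromatic nitrogen. Going by the values given here, no measured pair shows such a change, so the expectation rests on the size of the group alone. Compound 4 is expected to be markedly more lipophilic, with a step from compound 2 estimated at a number 1.80 log units higher from compound 2 to compound 4 (beyond the scatter). In this assay compound 4 is estimated at 3.2, within a range from 2.6 to 3.8.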

Compound 4, distribution coefficient: 3
The estimate for compound 4 lay 0.20 log units above the measured number; low and high end bracket the measured number.
By their numbers in this assay, from the lowest: compound 3; then compounds 2 and 1 (each within the scatter of the next); then compound 4.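

In this assay, benzyl in place of hydrogen on an aromatic nitrogen gives a number 1.60 log units higher from compound 2 to compound 4 (beyond the scatter), the first step measured at this position. It shows that a change on this nitrogen, next to the ring atom that bears a large group, can shift the number by a large amount. No measurement at hand gives a reason for the size of this step.

This single pair leaves open whether methyl, or a benzyl carrying an amine or a carboxylic acid, would give a smaller step. Going by these compounds, whether benzyl would give a similar step on compound 3 also stays open.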